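A Carboxylic Acid Side Chain Gains a Nitrogen Linker

This account rests on a few compounds, and the source may have more. Where it says the series, first, only, none or still open, it means among the compounds named here.

The series shares a fused bicyclic core carrying a nitrile, a biaryl arm and a variable side chain. In a physicochemical assay for lipophilicity, read by HPLC, at pH 7.5 (on this read-out higher numbers stand for higher lipophilicity and lower numbers for lower lipophilicity), compound 1 `CCOc1ccccc1-c1ccc(-c2nc3cnccc3c(C[C@H](C)C(=O)O)c2C#N)cc1` gives 2.2, the lowest of the three numbers. Compound 2 `CC[C@@H](Nc1c(C#N)c(-c2ccc(-c3cccc(OC)c3)cc2)nc2cnccc12)C(N)=O` gives 2.7 in this assay, beyond the scatter above compound 1, and compound 3 `CCOc1ccccc1-c1ccc(-c2nc3cncc(Cl)c3c(N[C@H](CC)C(N)=O)c2C#N)cc1` gives 3.7, the furthest from compound 1. Compound 4 `CCOc1ccccc1-c1ccc(-c2nc3cnccc3c(N[C@H](CC)C(=O)O)c2C#N)cc1` has not yet been measured. The change from compound 1 to compound 4 is (1-carboxypropyl)amino in place of 2-carboxypropyl on an aromatic carbon on an aromatic carbon ortho to a cyano group and opposite the ring nitrogen. For the measured compounds named here, no step between measured compounds matches this change. Compound 4 is expected to shift by a number 0.20 log units higher from compound 1 to compound 4 (within the scatter), within the scatter. Compound 4 is estimated at 2.4, between 1.8 and 3.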

Compound 4, distribution coefficient: 2.1
Compound 4: the middle estimate sits 0.30 log units above what was measured; the measured number falls inside the stated range.
By their numbers in this assay, from the lowest: compounds 4 and 1 (each within the scatter of the next); then compound 2; then compound 3.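

In this assay, placing (1-carboxypropyl)amino in place of 2-carboxypropyl on the aromatic carbon ortho to a cyano group gives a number 0.10 log units lower from compound 1 to compound 4 (within the scatter) and so leaves the read-out unchanged within the scatter. For the compounds shown here, this is the first comparison of compounds that differ in one place, and it shows that this side chain can gain the nitrogen linker without a step beyond the scatter. Nothing available explains this result.

As far as these compounds go, whether an oxygen linker would behave the same way remains open. So does whether a methyl ester or a longer chain in place of this side chain would stay within the scatter.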